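The source may hold more compounds than are shown below. What is called first, only, known or untested is meant among the compounds shown, and "the series" means these compounds.

Values in an ADME assay on J774.1 cells (Mus musculus) for cytotoxicity, read by resazurin assay, with a stated time of 48 h; on this read-out lower numbers stand for stronger inhibition and higher numbers for weaker inhibition:
- compound 1 `CCCCn1cc(C(=O)NCc2ccccc2)c(=O)c2cc(F)c(N(C)C)cc21`: > 100000 nM (a limit of the assay)
- compound 2 `CCCCn1cc(C(=O)NCc2ccccc2)c(=O)c2cc(F)c(N(C)Cc3ccccc3)cc21`: 86000 nM

Going by the values given here, compound 2, at 86000 nM, holds the only number so far. The other reading is a limit, held by compound 1: the limit of > 100000 nM in this assay, at which 1 of the 2 values shown sits.

Compound 3 `CCCCn1cc(C(=O)O)c(=O)c2cc(F)c(N(C)Cc3ccccc3)cc21` has hydroxy in place of benzylamino on a carbonyl carbon. Cut one bond further out, this is benzylcarbamoyl to carboxy.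

Among the compounds with values here, the only measured step is an at least 1.1-fold lower number from compound 1 to compound 2 (0.06 log units; that floor lies within the scatter). Within the data shown here, it changes a different part of the structure, so no measured step gives a size for this change. The expectation in this assay therefore starts from compound 2 at 86000 nM, with a small move towards a higher number, possibly none beyond the scatter. A limit reading for compound 3 would not be surprising.

The expected change is a 1.4-fold higher number from compound 2 to compound 3 (0.14 log units; within the scatter). Compound 3 is estimated at 120000 nM, with an expected range of 50000 nM to 300000 nM.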

Compound 3, half-maximal inhibitory concentration: 43200 nM
Estimate against measurement, compound 3: 2.8-fold (0.44 log units) above; measured number below the stated range.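

In this assay, the carbonyl carbon now has its first measured step, with hydroxy in place of benzylamino: a 2.0-fold lower number from compound 2 to compound 3 (0.30 log units; within the scatter). This swap takes away the benzylamino group, with its 8 heavy atoms and six-membered aromatic ring, and leaves a single oxygen, yet the readings of the carboxy and benzylcarbamoyl compounds are not separated. The benzylcarbamoyl group is therefore not needed for a numerical reading in this series, a point the earlier step could not address, since it changed only the substituent on the nitrogen on the aromatic ring.

Compound 1 remains a limit and not a number in this assay, so its step to compound 2 gives only a floor: the limit of > 100000 nM in this assay, at which 1 of the 3 values shown sits. On these data alone, whether other groups on this carbonyl carbon, such as a methyl ester or a primary amide, stay within the same narrow span remains open, as does the effect of a longer chain in place of the butyl chain on the shared core.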